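A Methyl on the Saturated Ring: Expecting Little Change

The compounds below may be only part of what the source reports. "The series", "measured", "known", "first", "only" and "open" are said of these compounds alone.

Compound 2 `COc1cc2c(Oc3ccc(NC(=O)c4nnn(-c5ccc(F)cc5)c4C(F)(F)F)cc3F)ccnc2cc1OCCCN1CCCCC1` stands alongside compound 1 `COc1cc2c(Oc3ccc(NC(=O)c4nnn(-c5ccc(F)cc5)c4C(F)(F)F)cc3F)ccnc2cc1OCCCN1CCCC1` on the two numbers in hand. In a functional assay on A549 cells (Homo sapiens) for cytotoxicity, read by MTT assay, with a stated time of 72 h (on this read-out higher numbers stand for weaker inhibition and lower numbers for stronger inhibition), compound 2 gives 110 nM, and in this assay compound 1 gives 80 nM. Among the measured compounds shown here, the only measured step, a 1.4-fold higher number from compound 1 to compound 2 (0.14 log units; within the scatter), lies within the scatter, so the two numbers cannot be told apart. Compound 3 `COc1cc2c(Oc3ccc(NC(=O)c4nnn(-c5ccc(F)cc5)c4C(F)(F)F)cc3F)ccnc2cc1OCCCN1CCC(C)CC1` differs from compound 2 by methyl in place of hydrogen on a saturated ring carbon. The step from compound 1 to compound 2 is the one that bears on this change, as both alter the ring at the end of the chain, and it was small. Nothing in these two numbers suggests that a methyl at this place should move the read-out beyond the scatter. The step from compound 2 to compound 3 in this assay is therefore expected to be no change at the digits printed from compound 2 to compound 3 (within the scatter). Compound 3 is estimated at 110 nM, between 50 nM and 250 nM.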

Compound 3, half-maximal inhibitory concentration: 120 nM
Beside the measured number, compound 3's estimate is 1.1-fold (0.04 log units) below it, and the stated range covers the measured number.
By their numbers in this assay, from the lowest: compounds 1, 2 and 3 (each within the scatter of the next).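

In this assay the methyl on the ring carbon, three ring bonds from the ring nitrogen, appears as a 1.1-fold higher number from compound 2 to compound 3 (0.04 log units; within the scatter) and so adds no readable change at this position of the piperidin-1-yl ring. The wider step, a 1.5-fold higher number from compound 1 to compound 3 (0.18 log units; within the scatter), also stays inside the scatter, which means that pyrrolidin-1-yl, piperidin-1-yl and 4-methylpiperidin-1-yl at the end of the chain cannot be told apart on this read-out. No supporting measurement bears on this result.

The compounds shown leave open whether a hydroxyl or a carboxylic acid on this same ring carbon would read alike. They also leave open what a morpholine or a piperazine in place of the whole ring, or a longer chain carrying it, would give.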